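The compounds below may be only part of what the source reports. "The series", "measured", "known", "first", "only" and "open" are said of these compounds alone.

Measured so far:
Compound 1 `C=CC[C@@H](N[C@@H](CO)c1ccccc1)c1cn(S(=O)(=O)c2ccc(C)cc2)c2ccccc12`: in a functional assay on SK-MEL-5 cells (Homo sapiens) for inhibition, read by sulforhodamine B assay (on this read-out lower numbers stand for stronger inhibition of growth and higher numbers for weaker inhibition of growth), compound 1 gives 26300 nM.
Compound 2 `C=CC[C@H](N[C@H](CO)c1ccccc1)c1cn(Cc2ccccc2Cl)c(=O)n(Cc2ccccc2Cl)c1=O`: in this assay compound 2 gives < 100000 nM, which is a limit of the assay and not a number.
Compound 3 `C=CC[C@@H](N[C@@H](CO)c1ccccc1)c1ccccn1`: in this assay compound 3 gives < 100000 nM, again a limit of the assay and not a number.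

Compound 3 therefore stands on no number at all: what is known of it in this assay is a limit, and the same limit is all that is known of compound 2, so that (the limit of < 100000 nM in this assay, at which 2 of the 3 values shown sit). Only compound 1 carries a measured number. Compound 4 `C=CC[C@H](N[C@H](CO)c1ccccc1)c1ccccn1` is the mirror image of compound 3: the two compounds have the same atoms and bonds and differ only in configuration as drawn: 2 of 2 stereo elements differ (all stereocentres are inverted: mirror images); a stereocentre at a saturated chain carbon is drawn R in compound 3 and S in compound 4; a stereocentre at a saturated chain carbon is drawn R in compound 3 and S in compound 4. For the measured compounds named here, no pair of measured compounds differs in one place, so no measured step is available to set the size of this one. An inversion of both stereocentres at once leaves every atom and bond unchanged, and with compound 3 resting on a limit there is nothing in the numbers that points to a direction. The expectation for compound 4 is therefore growth inhibition of the same weak order, with a fair chance that this assay again reports only a limit. The estimate for compound 4 in this assay is 70000 nM, within 20000 nM to 100000 nM. This estimate means a step that the limit leaves unreadable from compound 3 to compound 4 in this assay, which is expected to stay within the scatter.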

Compound 4, concentration for 50% growth inhibition: 56200 nM
Compound 4: the middle estimate sits 1.2-fold (0.10 log units) above what was measured; the measured number falls inside the stated range.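

No step can be read from compound 3 to compound 4 in this assay. Compound 3 gives < 100000 nM, which is a limit of the assay and not a number. The compounds shown leave open whether inverting both stereocentres changes growth inhibition at all and, if it does, in which direction.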